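Benzyl-ether substituent swap in a diamine aryl ether series

The source may hold more compounds than are shown below. What is called first, only, known or untested is meant among the compounds shown, and "the series" means these compounds.

The series shares one core, varied only at the benzyl ring. Compound 1 `COc1cccc(OC)c1OCCNCCOc1ccccc1OCc1cccc(C)c1` gives 8.85 in a functional assay on thoracic aorta for antagonist activity at Alpha-1D adrenergic receptor (Rattus norvegicus); on this read-out lower numbers stand for lower potency and higher numbers for higher potency (the scale is a negative logarithm); compound 2 `COc1cccc(OC)c1OCCNCCOc1ccccc1OCc1cccc([N+](=O)[O-])c1` gives 9.28; compound 3 `COc1cccc(COc2ccccc2OCCNCCOc2c(OC)cccc2OC)c1` gives 9.12. Compound 3 stands second of the three, with a number 0.16 log units lower from compound 2 to compound 3 (within the scatter) and a number 0.27 log units higher from compound 1 to compound 3 (within the scatter), both within the scatter. Compound 4 `CCOc1ccc(COc2ccccc2OCCNCCOc2c(OC)cccc2OC)cc1` carries 4-ethoxyphenyl in place of 3-methoxyphenyl on a saturated chain carbon bound to an oxygen on an aromatic ring. Among the measured compounds shown here, the steps that bear on this ring are a number 0.43 log units higher from compound 1 to compound 2 (beyond the scatter) and a number 0.27 log units higher from compound 1 to compound 3 (within the scatter), small or modest changes; the new ring keeps one acceptor. A step of about the same size, in no fixed direction, is therefore expected, and compound 4 is estimated at 9, range 8.5 to 9.5, meaning a number 0.12 log units lower from compound 3 to compound 4 (within the scatter).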

Compound 4, negative logarithm of the antagonist equilibrium constant: 9.11
Beside the measured number, compound 4's estimate is 0.11 log units below it, and the stated range covers the measured number.
By their numbers in this assay, from the lowest: compounds 1, 4, 3 and 2 (each within the scatter of the next, the first and the last beyond it).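

In this assay the 4-ethoxyphenyl group gives a number 0.01 log units lower from compound 3 to compound 4 (within the scatter) and a number 0.17 log units lower from compound 2 to compound 4 (within the scatter) and also a number 0.26 log units higher from compound 1 to compound 4 (within the scatter) as its three steps. This position on the saturated chain carbon therefore tolerates 4-ethoxyphenyl in place of 3-methoxyphenyl, 3-nitrophenyl or 3-methylphenyl, so a changed substituent name and ring position together leave the read-out within the scatter. No supporting data on why this holds accompany the result.

The separate contributions of the ethoxy group and its ring position remain open, since 3-ethoxyphenyl and 4-methoxyphenyl are not among the compounds shown. As far as these compounds go, whether the position also accepts an amine or a carboxylic acid on this ring, or a longer chain, stays open too.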